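The source may hold more compounds than are shown below. What is called first, only, known or untested is meant among the compounds shown, and "the series" means these compounds.

Working notes on the series. Compound 1 `CCOC(=O)c1sc(-c2cccc(NC(=O)c3ccc(C(C)(C)C)cc3)c2)nc1Nc1ccc(N2CCN(C)CC2)cc1` has "not determined" (no result reported) in a functional assay on Ramos cells (Homo sapiens) for antiproliferative activity, read by CCK-8 assay, with a stated time of 72 h; a lower number here means a stronger inhibitor, a higher number a weaker inhibitor. Compound 2 `CCOC(=O)c1sc(-c2cccc(NC(=O)c3ccc(C#N)cc3)c2)nc1Nc1ccc(N2CCN(C)CC2)cc1` gives 4280 nM in this assay. Compound 3 `CN1CCN(c2ccc(Nc3nc(-c4cccc(NC(=O)c5ccc(C(C)(C)C)cc5)c4)sc3C(N)=O)cc2)CC1` gives 8600 nM in this assay; it carries the higher of the two numbers in hand, but the gap to compound 2 lies within the scatter of this assay, so the two are not separable. Compound 4 `CN1CCN(c2ccc(Nc3nc(-c4cccc(NC(=O)c5ccc(C(F)(F)F)cn5)c4)sc3C(N)=O)cc2)CC1` is the next entry; it differs from compound 3 in one place: 5-(trifluoromethyl)pyridin-2-yl in place of 4-(tert-butyl)phenyl on a carbonyl carbon. For the measured compounds named here, no measured pair shows what this change does, so the expectation rests on compound 3 alone. The step from compound 3 to compound 4 in this assay is expected to be a 1.1-fold lower number from compound 3 to compound 4 (0.06 log units; within the scatter), that is, nothing beyond the scatter in either direction. Compound 4 is therefore estimated at 7500 nM in this assay, with a range from 2500 nM to 25000 nM.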

Compound 4, half-maximal inhibitory concentration: 19800 nM
Compound 4: middle estimate off by 2.6-fold (0.42 log units), on the low side; the range from low to high includes it.
By their numbers in this assay, from the lowest: compounds 2 and 3 (each within the scatter of the next); then compound 4.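

In this assay, for the compounds shown here, 5-(trifluoromethyl)pyridin-2-yl in place of 4-(tert-butyl)phenyl on the carbonyl carbon gives a 2.3-fold higher number from compound 3 to compound 4 (0.36 log units; beyond the scatter) and is the first single-place step, so the group at this position can move the number beyond the scatter. The change puts a ring nitrogen and a trifluoromethyl group where a carbon-only ring and a tert-butyl group stood, and it goes towards the weaker side. Nothing measured here bears on the reason for this step.

On these data alone, compound 3 and compound 4 change the ring nitrogen and the trifluoromethyl group together, so their separate contributions stay open. As far as these compounds go, how an unsubstituted phenyl or a cyclohexyl group on this carbonyl carbon would compare also stays open.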